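Swapping the Amide Cap for a Carbamate in Compound 4

The source may hold more compounds than are shown below. What is called first, only, known or untested is meant among the compounds shown, and "the series" means these compounds.

Measured so far:
- compound 1 `Cn1cncc1CN1CC(N(CC2CCN(C(=O)C3CCCC3)CC2)S(=O)(=O)c2ccccn2)Cc2cc(C#N)ccc21`: 0.5 10^-6 cm/s
- compound 2 `Cn1cncc1CN1CC(N(CC2CCN(C(=O)CC(F)(F)F)CC2)S(=O)(=O)c2ccccn2)Cc2cc(C#N)ccc21`: 0.5 10^-6 cm/s
- compound 3 `CC(C)NC(=O)N1CCC(CN(C2Cc3cc(C#N)ccc3N(Cc3cncn3C)C2)S(=O)(=O)c2ccccn2)CC1`: 0.6 10^-6 cm/s

These three compounds share one core and differ only in the group on the carbonyl carbon at the end of the chain. In an ADME assay on Caco-2 cells (Homo sapiens) for permeability, in the apical to basolateral direction (a higher number here means that the compound crosses the layer faster, a lower number that the compound crosses the layer more slowly), compound 3 gives 0.6 10^-6 cm/s. The step of a 1.2-fold higher number from compound 1 to compound 3 (0.08 log units; within the scatter) and the step of a 1.2-fold higher number from compound 2 to compound 3 (0.08 log units; within the scatter) both sit inside the scatter, and so does no change at the digits printed from compound 1 to compound 2 (within the scatter), so the three values are indistinguishable.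

Compound 4 `Cn1cncc1CN1CC(N(CC2CCN(C(=O)OC(C)(C)C)CC2)S(=O)(=O)c2ccccn2)Cc2cc(C#N)ccc21` is the next step: tert-butoxy in place of isopropylamino on a carbonyl carbon. The three measured steps all changed this same group and none moved the number, so a step of a 1.2-fold higher number from compound 3 to compound 4 (0.07 log units; within the scatter) is expected, that is, nothing beyond the scatter. For compound 4 the estimate in this assay is 0.7 10^-6 cm/s, with a range from 0.3 10^-6 cm/s to 1.8 10^-6 cm/s.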

Compound 4, apparent permeability: 15.5 10^-6 cm/s
Compound 4: middle estimate off by 22-fold (1.35 log units), on the low side; measured number above the stated range.
By their numbers in this assay, from the lowest: compounds 1, 2 and 3 (each within the scatter of the next); then compound 4.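

On this carbonyl carbon the cap can matter a great deal: in this assay, tert-butoxy gives a 26-fold higher number from compound 3 to compound 4 (1.41 log units; beyond the scatter) and likewise a 31-fold higher number from compound 2 to compound 4 (1.49 log units; beyond the scatter) as well as a 31-fold higher number from compound 1 to compound 4 (1.49 log units; beyond the scatter) at the same place. Of the four caps, only tert-butoxy joins the carbonyl carbon through an oxygen and only it stands apart, while the other three stay within the scatter of one another. Nothing available explains this jump. Still open, going by these compounds, is whether the oxygen or the tert-butyl end counts, which an isopropoxy or a methoxy cap, set against a tert-butylamino cap, would help separate.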